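This account rests on a few compounds, and the source may have more. Where it says the series, first, only, none or still open, it means among the compounds named here.

Measured compounds:
compound 1 `CCOC(=O)C1=C(Nc2ccccc2)S/C(=C\c2cccc(C(=O)O)c2)C1=O` gives 11700 nM in a functional assay on JAR cells (Homo sapiens) for inhibition, read by MTT assay, with a stated time of 72 h; a higher number here means a weaker inhibitor, a lower number a stronger inhibitor
compound 2 `CCOC(=O)C1=C(Nc2ccccc2)S/C(=C\c2ccccc2O)C1=O` gives 8000 nM in this assay
compound 3 `CCOC(=O)C1=C(Nc2ccccc2Br)S/C(=C\c2ccc[nH]2)C1=O` gives 8900 nM in this assay

All three measured values lie within the usual scatter of one another. Compound 3 sits in the middle of the three numbers, closest to compound 2 and furthest from compound 1, but neither gap is beyond the scatter, so no ordering among them can be claimed.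

Among the compounds with values here, the one measured step, a 1.5-fold lower number from compound 1 to compound 2 (0.17 log units; within the scatter), concerns the group on the double-bonded chain carbon and is itself within the scatter.

Compound 4 `CCOC(=O)C1=C(Nc2ccc([N+](=O)[O-])cc2)S/C(=C\c2ccc[nH]2)C1=O` has not been measured in this assay. It differs from compound 3 in one place: 4-nitrophenyl in place of 2-bromophenyl on an amine nitrogen. Within the data shown here, no measured pair in this set changes the group on the amine nitrogen, so no step bears directly on this change. Among the measured compounds shown here, the only available step, from compound 1 to compound 2, is within the scatter and concerns a different position. With three compounds all within the scatter of one another, the working expectation is that compound 4 shows no step beyond the scatter, expected as a 1.0-fold higher number from compound 3 to compound 4 (0.00 log units; within the scatter). Compound 4 is therefore estimated at 9000 nM, in the range 3000 nM to 27000 nM.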

Compound 4, half-maximal inhibitory concentration: 15600 nM
Compound 4: middle estimate off by 1.7-fold (0.24 log units), on the low side; measured number inside the range.
By their numbers in this assay, from the lowest: compounds 2, 3, 1 and 4 (each within the scatter of the next).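

In this assay, within the data shown here, the first measured change on the amine nitrogen, 4-nitrophenyl in place of 2-bromophenyl, gives a 1.8-fold higher number from compound 3 to compound 4 (0.24 log units; within the scatter), so the step stays within the scatter. The earlier compounds shown here left this position untested; this pair shows that, with the rest of the molecule held constant, these two substituted phenyl groups cannot be told apart here, and no step read so far lies beyond the scatter. Nothing measured alongside these numbers offers an explanation for the step.

This single pair changes both the substituent and its place on the phenyl ring, so the two cannot be separated; 4-bromophenyl or 2-nitrophenyl on the amine nitrogen, with the rest of compound 3 unchanged, would be needed to pull them apart. Also open, from the compounds shown here alone, is whether any group at this position moves the number beyond the scatter, for instance a phenyl ring carrying a carboxylic acid or an amine, or a simple alkyl chain in place of the ring.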